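A few compounds are considered here, and "the series" means these few. Any claim that something is new, unique, unknown or untested is made for them only; others in the source may bear on it.

Measured compounds in a functional assay on CCRF-CEM cells (Homo sapiens) for antiproliferative activity, read by MTT assay, with a stated time of 3 days; on this read-out lower numbers stand for stronger inhibition and higher numbers for weaker inhibition:
compound 1 `CCCCCCC#Cc1cn(C/C=C/CN2C(=O)c3ccccc3C2=O)c(=O)[nH]c1=O` — 28000 nM
compound 2 `O=C1c2ccccc2C(=O)N1C/C=C\Cn1cc(C#Cc2ccc(Br)cc2)c(=O)[nH]c1=O` — 80000 nM
compound 3 `CCCCCc1ccc(C#Cc2cn(C/C=C\CN3C(=O)c4ccccc4C3=O)c(=O)[nH]c2=O)cc1` — 102000 nM

Compound 1 gives the lowest number of the three in this assay; the gap to compound 2, the nearest, and to compound 3, the furthest, both lie beyond the scatter. For the measured compounds named here, the only single-point step among the measured compounds, a 1.3-fold higher number from compound 2 to compound 3 (0.11 log units; within the scatter), is a change on an aromatic carbon and lies within the scatter.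

Compound 4 `CCCCCCCCC#Cc1cn(C/C=C/CN2C(=O)c3ccccc3C2=O)c(=O)[nH]c1=O` differs from compound 1 as follows: ethyl in place of hydrogen on a saturated chain carbon, six bonds along the chain from a triple-bonded carbon. Going by the values given here, no measured step probes this same kind of lengthening on the saturated chain; the step from compound 2 to compound 3, where pentyl replaces bromo, is the nearest analogy and shows no movement beyond the scatter. On that basis no step beyond the scatter is expected in this assay from compound 1 to compound 4, so the number for compound 4 is expected near that of compound 1, as a 1.1-fold lower number from compound 1 to compound 4 (0.05 log units; within the scatter). For compound 4 the estimate is 25000 nM, with a range from 10000 nM to 65000 nM.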

Compound 4, half-maximal inhibitory concentration: > 250000 nM
Compound 4: a limit, no number; the forecaster's own chance of this, stated with the estimate: 10%; middle value at least 10-fold (1.00 log units) from the limit.
By their numbers in this assay, from the lowest: compound 1; then compounds 2 and 3 (each within the scatter of the next). At a limit, above all of these: compound 4.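

In this assay, the saturated chain carbon six bonds along the chain from a triple-bonded carbon does not tolerate lengthening: ethyl in place of hydrogen there gives an at least 8.9-fold higher number from compound 1 to compound 4 (0.95 log units; beyond the scatter). The only earlier single-point step, a 1.3-fold higher number from compound 2 to compound 3 (0.11 log units; within the scatter), was a change on an aromatic carbon, so the series had not yet shown a step beyond the scatter from a change of one group. Compound 4 has a limit and not a number, so its step sets only a minimum size: the limit of > 250000 nM in this assay, at which 1 of the 4 values shown sits.

This single pair does not tell whether the rise in the number sets in gradually or abruptly with chain length. Also open, from the compounds shown here alone, is how a shorter butyl chain, or an amine or a carboxylic acid at this same carbon, would read in this assay.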